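A few compounds are considered here, and "the series" means these few. Any claim that something is new, unique, unknown or untested is made for them only; others in the source may bear on it.

Measured so far:
compound 1 `CCO[C@@H]1O[C@H](CNC(=O)c2ccc(S(N)(=O)=O)cc2)[C@@H](O)[C@H](O)[C@H]1N`: 1.56 mL/min/kg in an ADME assay on microsomes from liver (Mus musculus) for metabolic stability; a higher number here means faster removal of the compound, a lower number slower removal
compound 2 `CCO[C@@H]1O[C@H](CNC(=O)c2ccc(S(N)(=O)=O)cc2)[C@H](O)[C@H](O)[C@H]1O`: 1.5 mL/min/kg
compound 3 `CCCO[C@@H]1O[C@H](CNC(=O)c2ccc(S(N)(=O)=O)cc2)[C@H](O)[C@H](O)[C@H]1O`: 1.38 mL/min/kg

Within the data shown here, the three measured compounds sit close together in this assay, and no step among them reaches beyond the scatter. Compound 1 and compound 2 share most of their structure but differ in their cores; that difference is not broken down here, and their values show no separation. Compound 3 differs from compound 2 by methyl in place of hydrogen on a saturated chain carbon, two bonds along the chain from an oxygen on a saturated carbon, and this change gave a 1.1-fold lower number from compound 2 to compound 3 (0.04 log units; within the scatter).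

Compound 4 `CCCO[C@@H]1O[C@H](CNC(=O)c2ccc(S(N)(=O)=O)cc2)[C@@H](O)[C@H](O)[C@H]1N` is not yet measured. It differs from compound 1 by methyl in place of hydrogen on a saturated chain carbon, two bonds along the chain from an oxygen on a saturated carbon, the same change that was made from compound 2 to compound 3. For compound 4 the expected step is a 1.1-fold lower number from compound 1 to compound 4 (0.03 log units; within the scatter). That expectation rests on a 1.1-fold lower number from compound 2 to compound 3 (0.04 log units; within the scatter), which stayed within the scatter. Compound 4 is therefore estimated to give 1.45 mL/min/kg, with a plausible range from 1 mL/min/kg to 2.1 mL/min/kg.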

Compound 4, clearance: 1.42 mL/min/kg
Beside the measured number, compound 4's estimate is 1.0-fold (0.01 log units) above it, and the stated range covers the measured number.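

In this assay, going from ethoxy to propoxy gave a 1.1-fold lower number from compound 1 to compound 4 (0.04 log units; within the scatter). Among these compounds, the same change therefore reads alike on the two cores: the same change on two cores in this assay, a 1.1-fold lower number (0.04 log units; within the scatter) from compound 2 to compound 3 and a 1.1-fold lower number (0.04 log units; within the scatter) from compound 1 to compound 4, 1.0-fold (0.00 log units) apart, within the scatter of two such steps Both steps lie within the scatter, so this shows only that the change has no effect that can be told apart from the scatter on either core; it does not show a real effect that carries from one core to the other, nor how the change would behave on any further core.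

The compounds shown leave open what a longer chain, such as butoxy, would give in this place on either core. They also leave open whether an amine or a carboxylic acid on that chain would give a step beyond the scatter.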